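Adding Fluoro to Compound 1: Expected Maximal Response

A few compounds are considered here, and "the series" means these few. Any claim that something is new, unique, unknown or untested is made for them only; others in the source may bear on it.

Measured so far in a functional assay with 5-hydroxytryptamine receptor 1B (Homo sapiens) as the target, read by radioligand binding and GTPgammaS binding; a higher number here means a larger maximal response, a lower number a smaller maximal response:
- compound 1, `c1ccc(CC2CCN(CCCc3c[nH]c4ccc(-n5cnnc5)cc34)CC2)cc1`, gives 62%
- compound 2, `CN(Cc1ccccc1)C1CCN(CCCc2c[nH]c3ccc(-n4cnnc4)cc23)CC1`, gives 77%

Compound 1 stands lowest of these two numbers; the nearest is compound 2, and the step of a number 15 percentage points higher from compound 1 to compound 2 (beyond the scatter) lies beyond the scatter. That step swaps a benzyl on a saturated ring carbon for benzyl(methyl)amino.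

Compound 3, `FC1(Cc2ccccc2)CCN(CCCc2c[nH]c3ccc(-n4cnnc4)cc23)CC1`, differs from compound 1 in one place: fluoro in place of hydrogen on a saturated ring carbon. Among the compounds with values here, the only measured step changes the large group attached to the saturated ring carbon, not a hydrogen on that ring, so it does not bear on this change, and no other measured pair involves a fluoro. Within the data shown here, nothing among the measured compounds therefore points to a rise or a fall in this assay, and the expectation is a step no larger than the scatter, in either direction. For compound 3 the estimated value is 62%, with a range from 45% to 80%. That estimate means a step of no change at the digits printed from compound 1 to compound 3 (within the scatter) is expected, a change that stays within the scatter of this assay.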

Compound 3, largest response reached (reported as efficacy), in percent of the reference or control that the assay uses: 67%
Compound 3: the middle estimate sits 5 percentage points below what was measured; the measured number falls inside the stated range.
By their numbers in this assay, from the lowest: compounds 1, 3 and 2 (each within the scatter of the next, the first and the last beyond it).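

Within the data shown here, until now, the only measured step in this assay changed the large group on the ring, and that step went beyond the scatter; the present pair is the first to probe a ring hydrogen, on a saturated ring carbon of the six-membered ring with one nitrogen. Fluoro in place of hydrogen there gives a number 5 percentage points higher from compound 1 to compound 3 (within the scatter) and so, on this one background, a single fluorine atom leaves the maximal response indistinguishable from that of compound 1. No supporting data bear on why the response holds when this atom is exchanged.

One pair cannot show whether the same exchange would hold on the background of compound 2, which carries benzyl(methyl)amino. It also leaves open whether a hydroxyl or a methyl at this place would likewise stay within the scatter, or would shift the response as clearly as the other change does in a number 15 percentage points higher from compound 1 to compound 2 (beyond the scatter) and so mark this ring carbon as sensitive after all.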